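The compounds below may be only part of what the source reports. "The series", "measured", "known", "first", "only" and "open" are said of these compounds alone.

Working notes on the series. Two compounds carry a measurement in a functional assay on HepG2 cells (Homo sapiens) for cytotoxicity, read by MTT assay, with a stated time of 72 h; a lower number here means a stronger inhibitor, a higher number a weaker inhibitor. Compound 1 `COc1ccc2ccc(=O)oc2c1C1=NNC(c2cccs2)C1` gives 11 nM in this assay. Compound 2 `COc1ccc2ccc(=O)oc2c1C1=NN(c2ccccc2)C(c2ccc(C)cc2)C1` gives 51 nM in this assay. Compound 2 thus stands with the higher of the two numbers, and its gap to compound 1 lies beyond the scatter; the two structures differ in more than one place, so the gap is not traced to a single change.

Compound 3 `COc1ccc2ccc(=O)oc2c1C1=NN(c2ccccc2)C(c2cccs2)C1` is the next compound. Relative to compound 2 the change is thiophen-2-yl in place of 4-methylphenyl on a saturated ring carbon; nothing else moves. Going by the values given here, no step of this kind between measured compounds exists in the set. A move toward a lower number in this assay is expected, because compound 1 with the same thiophen-2-yl group gives 11 nM, but the phenyl group on the ring nitrogen stays, so the expected step from compound 2 to compound 3 is a 2.0-fold lower number from compound 2 to compound 3 (0.31 log units; beyond the scatter). Compound 3 is estimated at 25 nM, with a range from 8 nM to 80 nM.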

Compound 3, half-maximal inhibitory concentration: 15 nM
Beside the measured number, compound 3's estimate is 1.7-fold (0.22 log units) above it; the range from low to high includes it.
By their numbers in this assay, from the lowest: compounds 1 and 3 (each within the scatter of the next); then compound 2.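

In this assay, going by these compounds alone, the group on the saturated ring carbon matters: thiophen-2-yl in place of 4-methylphenyl gives a 3.4-fold lower number from compound 2 to compound 3 (0.53 log units; beyond the scatter) and this is the only single-place step at this position so far. With thiophen-2-yl held, phenyl in place of hydrogen on the ring nitrogen gives a 1.4-fold higher number from compound 1 to compound 3 (0.13 log units; within the scatter) and so stays within the scatter, which means this pair shows no cost for phenyl at that nitrogen. No measurement in hand accounts for the step at the saturated ring carbon.

Open, on these data alone, is whether the step belongs to thiophen-2-yl in particular, or whether furan-2-yl or unsubstituted phenyl on the same carbon would read the same way. Also open, as far as these compounds go, is how a methyl group or an acetyl group on the ring nitrogen would read against hydrogen and phenyl.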